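Closing a Chain into a Ring: Expected Solubility

The source may report more compounds than this note shows. Statements on the series, on what has been measured and on what is new or still open speak of the compounds shown alone.

Compound 1 `CC(C)NC(=O)CC(c1ccc(-c2ccc3cccc(F)c3c2)[nH]c1=O)C(C)C`: 18000 nM
Compound 2 `CC(C)[C@H](C[C@H]1CCNC1=O)c1ccc(-c2ccc3cccc(F)c3c2)[nH]c1=O`: 26800 nM

Of the compounds shown here, two have been measured in a physicochemical assay for solubility, in phosphate buffer, measured as kinetic solubility; on this read-out higher numbers stand for higher solubility and lower numbers for lower solubility. Compound 1 gives 18000 nM, the lower of the two numbers, and compound 2 gives 26800 nM; the two values sit within the usual scatter of each other, so no difference between them can be claimed. Compound 3 `CC(C)C(/C=C1\CCNC1=O)c1ccc(-c2ccc3cccc(F)c3c2)[nH]c1=O` has not yet been measured. It differs from compound 1 by a group of 7 heavy atoms (5 carbon, 1 nitrogen, 1 oxygen; one five-membered non-aromatic ring with 1 hetero atom) in place of a group of 7 heavy atoms (5 carbon, 1 nitrogen, 1 oxygen; no ring), on a saturated chain carbon bound to an aromatic carbon and a saturated chain carbon. Among the compounds with values here, no measured pair shows what such a change does, so only a modest step in this assay, slightly downward or none beyond the scatter, is expected. Compound 3 is estimated at 12000 nM, between 4000 nM and 36000 nM. The expected step is a 1.5-fold lower number from compound 1 to compound 3 (0.18 log units; within the scatter).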

Compound 3, solubility: 20700 nM
Estimate against measurement, compound 3: 1.7-fold (0.24 log units) below; low and high end bracket the measured number.
By their numbers in this assay, from the lowest: compounds 1, 3 and 2 (each within the scatter of the next).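

Putting the five-membered non-aromatic ring in place of the open (isopropylcarbamoyl)methyl chain, on the saturated chain carbon, gives a 1.2-fold higher number from compound 1 to compound 3 (0.06 log units; within the scatter) in this assay. At this position, then, closing the chain into this ring, with one more double bond outside aromatic rings, produces no difference that can be claimed. Nothing measured here offers an explanation for this result.

From the compounds shown here alone, whether an amine or a carboxylic acid on the ring would shift the number remains open. So does the effect of a six-membered ring at this place.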